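This account rests on a few compounds, and the source may have more. Where it says the series, first, only, none or still open, it means among the compounds named here.

Measured so far:
- compound 1, `COc1cc(-c2cc(/C=C/C(=O)c3ccc(N)cc3)[nH]n2)cc(OC)c1OC` — 5100 nM
- compound 2, `COc1ccc(C(=O)/C=C/c2cc(-c3cc(OC)c(OC)c(OC)c3)n[nH]2)cc1OC` — 3330 nM

Both were tested in a functional assay on NCI-H460 cells (Homo sapiens) for inhibition, read by sulforhodamine B assay, with a stated time of 48 h; on this read-out lower numbers stand for stronger inhibition of growth and higher numbers for weaker inhibition of growth. Going by the values given here, on these two numbers compound 2 gives 3330 nM and stands at the lower end, but the only step between them, a 1.5-fold lower number from compound 1 to compound 2 (0.19 log units; within the scatter), lies within the scatter, so no order between compound 2 and compound 1 can be claimed.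

Compound 3, `COc1ccc(C(=O)/C=C/c2cc(-c3cc(OC)c(OC)c(OC)c3)n[nH]2)cc1`, has not been measured. It differs from compound 2 by hydrogen in place of methoxy on an aromatic carbon. Among the compounds with values here, the one measured step, from compound 1 to compound 2, also changes the group on the carbonyl carbon, and it was small; no step in this set removes a methoxy from a ring that keeps another methoxy. For this assay the expectation for compound 3 is therefore a step of a 1.1-fold higher number from compound 2 to compound 3 (0.02 log units; within the scatter), essentially none beyond the scatter. Compound 3 is estimated at 3500 nM, within 1200 nM to 10000 nM.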

Compound 3, concentration for total growth inhibition: 3750 nM
For compound 3 the middle estimate is 1.1-fold (0.03 log units) below the measured one, within the range that was stated.
By their numbers in this assay, from the lowest: compounds 2, 3 and 1 (each within the scatter of the next).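

Taking this one methoxy away, so that 3,4-dimethoxyphenyl becomes 4-methoxyphenyl, gives in this assay a 1.1-fold higher number from compound 2 to compound 3 (0.05 log units; within the scatter) and so no readable change. Going by these compounds alone, this is the first step here that isolates a single methoxy on that ring, whereas the earlier step exchanged the whole group on the carbonyl carbon. The swap of amino for methoxy on the aromatic carbon, a 1.4-fold lower number from compound 1 to compound 3 (0.13 log units; within the scatter), also allows no order, so all three aromatic groups remain indistinguishable in this assay, and nothing available offers an explanation for that.

The compounds shown leave open whether a different group at this position, such as a hydroxyl, a fluorine or the longer ethoxy chain, would move the number beyond the scatter. They also leave open what a plain phenyl, carrying hydrogen in place of the remaining methoxy, would give.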